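The compounds below may be only part of what the source reports. "The series", "measured", "known", "first", "only" and "open" are said of these compounds alone.

Measured so far:
- compound 1 `CN1C(=O)N(C)C2C1NC(=S)N2/N=C/C=C/c1ccccc1[N+](=O)[O-]` — 1760 nM
- compound 2 `CCN1C(=O)N(CC)C2C1NC(=S)N2/N=C/C=C/c1ccccc1` — 36100 nM

Compound 2 gives the highest of the two numbers in a functional assay on MCF7 cells (Homo sapiens) for inhibition, read by MTT assay, with a stated time of 72 h; on this read-out lower numbers stand for stronger inhibition and higher numbers for weaker inhibition; its nearest neighbour on this read-out is compound 1, whose value is lower by a margin beyond the usual scatter. The two compounds differ in more than one place, so the gap itself is not tied to a single change.

Compound 3 `CCN1C(=O)N(CC)C2C1NC(=S)N2/N=C/C=C/c1ccccc1[N+](=O)[O-]` is not yet measured. It follows from compound 2 by a single change: nitro in place of hydrogen on an aromatic carbon. Among the compounds with values here, compound 1 carries the same nitro group and gives 1760 nM in this assay, which is the only guide available for the direction.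

The number for compound 3 is expected to fall below that of compound 2, a step of a 6.0-fold lower number from compound 2 to compound 3 (0.78 log units; beyond the scatter), because compound 1 with its nitro group gives 1760 nM. Compound 3 is estimated at 6000 nM, with a range from 1500 nM to 25000 nM.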

Compound 3, half-maximal inhibitory concentration: 43900 nM
Beside the measured number, compound 3's estimate is 7.3-fold (0.86 log units) below it; the whole stated range lies below it.
By their numbers in this assay, from the lowest: compound 1; then compounds 2 and 3 (each within the scatter of the next).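

In this assay, phenyl to 2-nitrophenyl on the shared core gives a 1.2-fold higher number from compound 2 to compound 3 (0.08 log units; within the scatter), so on this diethyl pair a nitro group at this aromatic carbon, ortho to a large group, leaves the read-out unmoved. Within the data shown here, the nitro group therefore does not by itself carry a number like the one compound 1 shows (1760 nM), since compound 3 holds the same group and gives 43900 nM in this assay. The data offer no measurement that explains this flat step.

Still open is what the same change does on the core of compound 1, as the dimethyl partner lacking the nitro group is not among the compounds shown. Also open, from the compounds shown here alone, is how an amine or a methoxy group at this aromatic carbon, or a longer chain such as propyl in place of the ethyl groups, would read.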